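This account rests on a few compounds, and the source may have more. Where it says the series, first, only, none or still open, it means among the compounds named here.

Measured in a functional assay on HeLa cells (Homo sapiens) for cytotoxicity, read by WST assay, with a stated time of 48 h; a higher number here means a weaker inhibitor, a lower number a stronger inhibitor:
- compound 1 `COc1cc(C(c2ccc(O)c(OC)c2)[C@H](C)C(C)C)ccc1O`: 16000 nM
- compound 2 `COc1cc(C(c2ccc(O)c(OC)c2)[C@@H](C)[C@@H](C)CF)ccc1O`: 42000 nM

Of these two, compound 2 has the higher number at 42000 nM, which makes it the weaker inhibitor of the pair. Compound 3 `COc1cc(C(c2ccc(O)c(OC)c2)[C@@H](C)C(C)C)ccc1O` is still to be tested in this assay. It differs from compound 2 by one small exchange: hydrogen in place of fluoro on a saturated chain carbon, four bonds along the chain from two aromatic carbons. This is hydrogen in place of fluoro on a saturated chain carbon, four bonds along the chain from two aromatic carbons, and it turns 2-(fluoromethyl)-1-methylpropyl into 1,2-dimethylpropyl.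

Among the measured compounds shown here, only one measured step bears on this: a 2.6-fold higher number from compound 1 to compound 2 (0.42 log units; beyond the scatter). That step was modest and ran the opposite way, with fluoro entering. For the measured compounds named here, compound 1 carries the same 1,2-dimethylpropyl name as compound 3, but one chain carbon is drawn with the opposite handedness, and no measurement yet shows what handedness alone does. Reversing the step still points to a modest move towards a lower number. The expected change is a 2.3-fold lower number from compound 2 to compound 3 (0.37 log units; beyond the scatter). Compound 3 is estimated at 18000 nM, with an expected range from 8000 nM to 42000 nM.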

Compound 3, half-maximal inhibitory concentration: 19000 nM
Beside the measured number, compound 3's estimate is 1.1-fold (0.02 log units) below it; the range from low to high includes it.
By their numbers in this assay, from the lowest: compounds 1 and 3 (each within the scatter of the next); then compound 2.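

In this assay, hydrogen in place of fluoro is now seen as a clean exchange, giving a 2.2-fold lower number from compound 2 to compound 3 (0.34 log units; beyond the scatter). The earlier step between compound 1 and compound 2 could not show this, as it combined the fluoro change with a difference in handedness at one chain carbon. Handedness at that carbon can now be read separately, and the result is a 1.2-fold higher number from compound 1 to compound 3 (0.07 log units; within the scatter), a difference too small to distinguish from the usual scatter, so among the compounds shown the fluoro exchange is the change that moves the number beyond the scatter, and this reading of handedness is clean for one reason: the fact that compounds 1 and 3 differ only in the configuration as drawn

The compounds shown leave open whether another group at this saturated chain carbon, such as a hydroxyl, an amine or a carboxylic acid, would shift the number as fluoro does, or whether a longer chain in place of 1,2-dimethylpropyl would change it at all. They also leave open whether the same small differences would appear in any cell type other than the one tested here.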